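Inverting two ring centres of a peroxide acid

The compounds below may be only part of what the source reports. "The series", "measured", "known", "first", "only" and "open" are said of these compounds alone.

Compound 1 `C=C1CCCC(C)(C)C1CC[C@]1(C)CC[C@@H]([C@@H](C)C(=O)O)OO1` sits at the edge of a functional assay on NCI/ADR-RES cells (Homo sapiens) for inhibition; a lower number here means a stronger inhibitor of growth, a higher number a weaker inhibitor of growth: it gives only > 10000 nM, which is a limit of the assay rather than a number, as the limit of > 10000 nM in this assay, at which 1 of the 3 values shown sits, shows. Two relatives did yield numbers. Compound 2 `C=C1CCCC(C)(C)C1CC[C@]1(C)CC[C@H]([C@@H](C)C(=O)OC)OO1` gives 5670 nM in this assay. Compound 3 `C=C1CCC[C@H]2[C@](C)(CC[C@]3(C)CC[C@@H]([C@@H](C)C(=O)O)OO3)[C@@H](C)CC[C@]12C`, built on a different core, gives 770 nM. Compound 4 `C=C1CCCC(C)(C)C1CC[C@@]1(C)CC[C@H]([C@@H](C)C(=O)O)OO1` keeps every atom and bond of compound 1; the change is the two compounds have the same atoms and bonds; at least one stereo element is drawn with a configuration in one of them and without one in the other: 2 of 4 stereo elements differ; a stereocentre at a saturated ring carbon is drawn R in compound 1 and S in compound 4; a stereocentre at a saturated ring carbon is drawn S in compound 1 and R in compound 4. Going by the values given here, no measured pair shows how such an inversion shifts growth inhibition, and compound 1 supplies only a limit, so the direction is open. Compound 4 is therefore expected near 8000 nM, between 2000 nM and 30000 nM. That expectation amounts to a step of an at least 1.2-fold lower number from compound 1 to compound 4 (0.09 log units; that floor lies within the scatter).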

Compound 4, concentration for 50% growth inhibition: 8780 nM
Compound 4: the middle estimate sits 1.1-fold (0.04 log units) below what was measured; measured number inside the range.
By their numbers in this assay, from the lowest: compound 3; then compounds 2 and 4 (each within the scatter of the next). At a limit, above all of these: compound 1.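

Inverting both ring centres of the peroxide acid gives, in this assay, a step that can now be stated (an at least 1.1-fold lower number from compound 1 to compound 4 (0.05 log units; that floor lies within the scatter)). This step is only a floor, and it lies within the scatter, because compound 1 stands at a limit: the limit of > 10000 nM in this assay, at which 1 of the 4 values shown sits. The comparison needs further caution because the two drawings differ in how their configuration is defined: the fact that one of compounds 1 and 4 is drawn with a defined configuration and the other without, at the place where they differ.

From the compounds shown here alone, whether this inversion truly changes growth inhibition remains open. Also open, going by these compounds, are how it would act on the core of compound 3 and how an amide in place of the carboxylic acid would behave.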